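The compounds below may be only part of what the source reports. "The series", "measured", "known", "first", "only" and "open" are said of these compounds alone.

Measured compounds:
- compound 1, `C=C(Br)C(=O)Nc1ccc(/C=C2\SC(=O)N(Cc3ccc(C)cc3)C2=O)cc1`, gives 3700 nM in a functional assay on CCRF-CEM cells (Homo sapiens) for cytotoxicity, read by cell counting, with a stated time of 3 days; a higher number here means a weaker inhibitor, a lower number a stronger inhibitor
- compound 2, `CC(C)(C)c1ccc(CN2C(=O)S/C(=C\c3cccc(N)c3)C2=O)cc1`, gives 165000 nM in this assay

Of these two numbers, compound 1 holds the lower one, and its gap to compound 2 is well beyond the scatter of repeated measurements, so compound 1 is the stronger inhibitor of the pair. The two compounds differ in several places at once, so no single change can be credited for that gap.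

The step of interest goes from compound 1 to compound 3, `C=C(Br)C(=O)Nc1ccc(/C=C2\SC(=O)N(C)C2=O)cc1`, which has not yet been measured in this assay. The change is hydrogen in place of 4-methylphenyl on a saturated chain carbon bound to an amide-type nitrogen in a ring. Put another way, the 4-methylbenzyl group on the ring nitrogen of the shared core shrinks to a methyl group, while the rest of compound 1, including its bromoacrylamide arm, is kept.

Among the compounds with values here, no measured pair shows this change on its own, so the expectation rests on the outline of the two known values. For compound 3 the step of a 2.2-fold higher number from compound 1 to compound 3 (0.33 log units; beyond the scatter) is expected to be a moderate weakening, beyond the scatter. Compound 3 is estimated at 8000 nM, with a plausible range from 2500 nM to 25000 nM.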

Compound 3, half-maximal inhibitory concentration: 360 nM
Estimate against measurement, compound 3: 22-fold (1.35 log units) above; measured number outside the range, below it.
By their numbers in this assay, from the lowest: compound 3; then compound 1; then compound 2.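

Within the data shown here, this single change, with the bromoacrylamide arm and the rest of the shared core held fixed, gives a 10-fold lower number from compound 1 to compound 3 (1.01 log units; beyond the scatter) in this assay, the first reading of this position on its own. It shows that the 4-methylbenzyl group on the ring nitrogen is not required for activity in this pair: taking away the 4-methylphenyl part, with its seven carbon atoms and six-membered aromatic ring, leaves the stronger inhibitor, and a plain methyl group is enough. No measurement here bears on why the smaller group does better.

Going by these compounds, whether the gain goes on with a bare hydrogen on the ring nitrogen, or is kept with an ethyl group, a longer chain, or a chain ending in an amine or a carboxylic acid, stays open. Also open, on these data alone, is whether the same shrinking of the group would do the same in a compound without the bromoacrylamide arm, such as compound 2, so this single step cannot yet be read as a general rule for the series.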